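The compounds below may be only part of what the source reports. "The series", "measured", "known", "first", "only" and "open" are said of these compounds alone.

Measured compounds:
Compound 1 `CC1=CC[C@H]2[C@@H]1CC=C(C)[C@@H](CC[C@H]1[C@]3(C)CC[C@H](O)C(C)(C)O[C@H]3CC[C@@]1(C)O)C2(C)C` — in a functional assay on MCF7 cells (Homo sapiens) for antiproliferative activity, read by MTT assay, with a stated time of 72 h (a higher number here means a weaker inhibitor, a lower number a stronger inhibitor), compound 1 gives > 50000 nM, which is a limit of the assay and not a number.
Compound 2 `CC1=CC[C@H]2[C@H](CC[C@]2(C)O)C(C)(C)[C@@H]1CC[C@H]1[C@]2(C)CC[C@H](OC(=O)c3ccc(C)cc3)C(C)(C)O[C@H]2CC[C@@]1(C)O` — in this assay compound 2 gives > 50000 nM, again a limit of the assay and not a number.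

Compound 2 therefore stands at the limit of > 50000 nM in this assay, at which 2 of the 2 values shown sit; no numerical value is available to place it. Compound 3 `CC1=CC[C@H]2[C@H](CC[C@]2(C)O)C(C)(C)[C@@H]1CC[C@H]1[C@]2(C)CC[C@H](OC(=O)c3ccccc3C(F)(F)F)C(C)(C)O[C@H]2CC[C@@]1(C)O` differs from compound 2 by 2-(trifluoromethyl)phenyl in place of 4-methylphenyl on a carbonyl carbon. For the measured compounds named here, no step between measured compounds exists, and both measured values are limits, so no direction can be read from the data. The expected step is a number no higher from compound 2 to compound 3 (the limit leaves the size open), none beyond the scatter, with a limit again the most likely report. Compound 3 is estimated at 50000 nM, range 20000 nM to 100000 nM.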

Compound 3, half-maximal inhibitory concentration: 19200 nM
The estimate for compound 3 lay 2.6-fold (0.42 log units) above the measured number, outside the stated range (below it).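

The group on this carbonyl carbon can change the read-out in this assay: 2-(trifluoromethyl)phenyl in place of 4-methylphenyl gives an at least 2.6-fold lower number from compound 2 to compound 3 (0.41 log units; beyond the scatter) and opens a first measurable difference in the series. Compound 3 gives a number, whereas the other values remain limits of the assay and not numbers: the limit of > 50000 nM in this assay, at which 2 of the 3 values shown sit.

From the compounds shown here alone, the full size of the step stays open, as does whether the trifluoromethyl group alone accounts for it. Going by these compounds, how an amine, a carboxylic acid or a longer alkyl chain on this carbonyl carbon would read also remains open.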